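Flipping one ring stereocentre in a peroxide acid

The source may hold more compounds than are shown below. What is called first, only, known or untested is meant among the compounds shown, and "the series" means these compounds.

Compound 2, with structure `C=C1CCC[C@H]2[C@](C)(CC[C@]3(C)CC[C@@H]([C@@H](C)C(=O)O)OO3)[C@@H](C)CC[C@]12C`, is the strongest of the three measured compounds in a functional assay on MOLT-4 cells (Homo sapiens) for inhibition (on this read-out higher numbers stand for weaker inhibition of growth and lower numbers for stronger inhibition of growth), giving 840 nM; the nearest is compound 3 and the furthest compound 1. Compound 1 has structure `C=C1CCCC(C)(C)C1CC[C@]1(C)CC[C@@H]([C@@H](C)C(=O)O)OO1` and in this assay gives 7430 nM, while compound 3 has structure `C=C1CCCC(C)(C)C1CC[C@@]1(C)CC[C@H]([C@@H](C)C(=O)O)OO1` and gives 2160 nM.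

Compound 4, with structure `C=C1CCC[C@H]2[C@](C)(CC[C@]3(C)CC[C@H]([C@@H](C)C(=O)O)OO3)[C@@H](C)CC[C@]12C`, is not yet measured. It differs from compound 2 only as the two compounds have the same atoms and bonds and differ only in configuration as drawn: 1 of 7 stereo elements differ; a stereocentre at a saturated ring carbon is drawn S in compound 2 and R in compound 4. Among the compounds with values here, the only measured step that bears on a change of configuration is a 3.4-fold lower number from compound 1 to compound 3 (0.54 log units; beyond the scatter), but that step involved two stereocentres rather than one, so it is an imperfect guide. A single inversion at a saturated ring carbon could plausibly move the number in either direction, with a modest shift more likely than a large one.

On this basis compound 4 is expected to give 600 nM, with a range from 200 nM to 2500 nM. That estimate means a step of a 1.4-fold lower number from compound 2 to compound 4 (0.15 log units; within the scatter), expected but uncertain in direction.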

Compound 4, concentration for 50% growth inhibition: 980 nM
The estimate for compound 4 lay 1.6-fold (0.21 log units) below the measured number, within the range that was stated.
By their numbers in this assay, from the lowest: compounds 2 and 4 (each within the scatter of the next); then compound 3; then compound 1.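

In this assay, inverting this one saturated ring carbon gives a 1.2-fold higher number from compound 2 to compound 4 (0.07 log units; within the scatter), so the two configurations cannot be told apart on this read-out. Within the data shown here, this is the first clean reading of that single stereocentre, because nothing else changes: the fact that compounds 2 and 4 differ only in the configuration as drawn. The earlier step, a 3.4-fold lower number from compound 1 to compound 3 (0.54 log units; beyond the scatter), lies beyond the scatter but changes two stereocentres at once in a different compound pair, so it cannot show what either centre does alone, and the tolerance seen here is established only for compounds 2 and 4.

The compounds shown leave open whether the other stereocentre, inverted alone, would matter more in either series. They also leave open whether the tolerance would hold if a methyl ester or a primary amide stood in place of the carboxylic acid.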